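This account rests on a few compounds, and the source may have more. Where it says the series, first, only, none or still open, it means among the compounds named here.

Values in an ADME assay on MT4 cells (Homo sapiens) for cytotoxicity, read by MTT assay; on this read-out higher numbers stand for lower toxicity in this test and lower numbers for higher toxicity in this test:
- compound 1 `COc1ccc(C(=O)CSc2nc(Cc3c(Cl)cccc3Cl)c(C(C)C)c(=O)[nH]2)cc1`: > 14000 nM (a limit)
- compound 2 `CCc1c(Cc2c(F)cccc2Cl)nc(SCC(=O)c2ccc(F)cc2)[nH]c1=O`: > 57000 nM (a limit)
- compound 3 `CCc1c(Cc2c(F)cccc2Cl)nc(SCC(=O)c2ccc(OC)cc2)[nH]c1=O`: > 11000 nM (a limit)

Going by the values given here, none of the three compounds has a measured number so far. Compound 3 stands at > 11000 nM, which is only a limit.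

Next in the series is compound 4 `COc1ccc(C(=O)CSc2nc(Cc3c(F)cccc3Cl)c(C(C)C)c(=O)[nH]2)cc1`. The change is methyl in place of hydrogen on a saturated chain carbon bound to an aromatic carbon and a saturated chain carbon, so ethyl becomes isopropyl.

Among the compounds with values here, the only measured step is a step that the two limits leave unreadable from compound 2 to compound 3, and it concerns methoxy in place of fluoro, not this change. Within the data shown here, no measured step gives a size for it. The nearest evidence is compound 1, which also carries isopropyl and reads > 14000 nM, again a limit.

The expected result in this assay is a step that the limit leaves unreadable from compound 3 to compound 4, with no shift in either direction beyond the scatter. For compound 4 the estimate is 14000 nM, with an expected range of 5000 nM to 50000 nM, and another limit is the likely report.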

Compound 4, half-maximal cytotoxic concentration: > 11000 nM
Compound 4: only a limit was reported; the forecaster's own chance of this, stated with the estimate: 80%; the middle value lies beyond the limit too.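

In this assay, compound 4 gives > 11000 nM, a limit, so the steps to compound 4 from compound 3 and from compound 1 cannot be read. All four values shown are limits, which leaves open the size of any effect of ethyl to isopropyl or of fluoro in place of chloro.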